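The source may hold more compounds than are shown below. What is called first, only, known or untested is meant among the compounds shown, and "the series" means these compounds.

Working notes on the series.

Compound 1 `COc1cc2c(Oc3ccc(NC(=O)c4nn(-c5ccccc5C)c(=O)cc4C)cc3F)ccnc2cc1OCCCN1CCCCC1` is the reference point here. In a functional assay on NCI-H460 cells (Homo sapiens) for inhibition, read by MTT assay, with a stated time of 72 h (a higher number here means a weaker inhibitor, a lower number a stronger inhibitor), compound 1 gives 3220 nM. Compound 2 `COc1cc2c(Oc3ccc(NC(=O)c4nn(-c5ccccc5C)c(=O)cc4C)cc3F)ccnc2cc1OCCCN1CCC(C)CC1` carries the change (methyl in place of hydrogen on a saturated ring carbon); in this assay compound 2 gives 2260 nM, a step of a 1.4-fold lower number from compound 1 to compound 2 (0.15 log units; within the scatter). Compound 3 `COc1ccc(-n2nc(C(=O)Nc3ccc(Oc4ccnc5cc(OCCCN6CCCCC6)c(OC)cc45)c(F)c3)c(C)cc2=O)cc1` differs from compound 1 in the core by 4-methoxyphenyl in place of 2-methylphenyl on an aromatic nitrogen; in this assay compound 3 gives 3730 nM, a step of a 1.2-fold higher number from compound 1 to compound 3 (0.06 log units; within the scatter). All three measured numbers sit within the usual scatter of one another, so no order among them is claimed.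

Compound 4 `COc1ccc(-n2nc(C(=O)Nc3ccc(Oc4ccnc5cc(OCCCN6CCC(C)CC6)c(OC)cc45)c(F)c3)c(C)cc2=O)cc1` has not been measured. It differs from compound 3 by methyl in place of hydrogen on a saturated ring carbon, and this is the same change as the one from compound 1 to compound 2, at the same place on the saturated ring, so it occurs twice among these four compounds. The expectation for compound 4 in this assay is a step of a 1.4-fold lower number from compound 3 to compound 4 (0.14 log units; within the scatter), set beside the earlier step because a 1.4-fold lower number from compound 1 to compound 2 (0.15 log units; within the scatter) stayed within the scatter. Compound 4 is therefore expected to give about 2700 nM, with a plausible range from 1400 nM to 5400 nM.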

Compound 4, half-maximal inhibitory concentration: 4650 nM
Compound 4: middle estimate off by 1.7-fold (0.24 log units), on the low side; the measured number falls inside the stated range.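

In this assay, the step for 4-methylpiperidin-1-yl in place of piperidin-1-yl on the core of compound 3 is a 1.2-fold higher number from compound 3 to compound 4 (0.10 log units; within the scatter), and it does not differ from the same change on the core of compound 1: the same change on two cores in this assay, a 1.4-fold lower number (0.15 log units; within the scatter) from compound 1 to compound 2 and a 1.2-fold higher number (0.10 log units; within the scatter) from compound 3 to compound 4, 1.8-fold (0.25 log units) apart, within the scatter of two such steps. Going by these compounds alone, the change to 4-methoxyphenyl from 2-methylphenyl on an aromatic nitrogen gives a 2.1-fold higher number from compound 2 to compound 4 (0.31 log units; beyond the scatter), the one step here beyond the scatter, yet it does not differ from the same change made without the added methyl: the same change on two cores in this assay, a 1.2-fold higher number (0.06 log units; within the scatter) from compound 1 to compound 3 and a 2.1-fold higher number (0.31 log units; beyond the scatter) from compound 2 to compound 4, 1.8-fold (0.25 log units) apart, within the scatter of two such steps. Both changes therefore carry between these two cores without a difference that can be read, but four compounds spanning small steps neither prove that the changes add up exactly nor rule out a modest dependence on the core.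

Still open, going by these compounds, is whether this holds for another amine at the end of the chain, such as morpholine, or for a longer chain. Also open, on these data alone, is how an unsubstituted phenyl on the aromatic nitrogen would behave.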